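Cytotoxicity limits across a benzyl-triazole chromone series

The source may report more compounds than this note shows. Statements on the series, on what has been measured and on what is new or still open speak of the compounds shown alone.

Measured in an ADME assay on L02 cells (Homo sapiens) for cytotoxicity, read by MTT assay, with a stated time of 48 h; on this read-out higher numbers stand for weaker inhibition and lower numbers for stronger inhibition:
compound 1 `O=c1ccoc2cc(OCc3cn(Cc4cccc(F)c4)nn3)ccc12`: > 300000 nM, a limit of the assay
compound 2 `O=c1ccoc2cc(OCc3cn(Cc4ccc([N+](=O)[O-])cc4)nn3)ccc12`: > 300000 nM, a limit of the assay
compound 3 `N#Cc1ccc(Cn2cc(COc3ccc4c(=O)ccoc4c3)nn2)cc1`: > 300000 nM, a limit of the assay

Compound 1 stands at a limit, not at a number, so no order can be read among the three measured compounds. The three steps that link them, a step that the two limits leave unreadable from compound 1 to compound 2, a step that the two limits leave unreadable from compound 1 to compound 3 and a step that the two limits leave unreadable from compound 2 to compound 3, are all unreadable in size for the same reason: the limit of > 300000 nM in this assay, at which 3 of the 3 values shown sit. Nothing in these data points to any change at the saturated chain carbon bound to an aromatic nitrogen that moves this read-out off the limit.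

Compound 4 `COc1ccc(Cn2cc(COc3ccc4c(=O)ccoc4c3)nn2)cc1` is the next member, not yet measured. Its difference from compound 1 is 4-methoxyphenyl in place of 3-fluorophenyl on a saturated chain carbon bound to an aromatic nitrogen. Among the measured compounds shown here, the steps that bear on it are those from compound 1, with 4-nitrophenyl or 4-cyanophenyl in place of 3-fluorophenyl at the same place, and both left the value at the limit. The step from compound 1 to compound 4 is therefore expected to show nothing readable, a number no higher from compound 1 to compound 4 (the limit leaves the size open). Compound 4 is expected at 300000 nM, within 150000 nM to 600000 nM, most probably reported again only as a limit.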

Compound 4, half-maximal inhibitory concentration: > 300000 nM
Compound 4 was reported as a limit; the forecaster's own chance of this, stated with the estimate: 85%; the middle value lies on the limit itself.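

No new step can be read in this assay: the steps joining compound 4 to compound 1, compound 2 and compound 3 all stay unreadable, because the values end at the same limit: the limit of > 300000 nM in this assay, at which 4 of the 4 values shown sit.

The compounds shown leave open whether any change on the saturated chain carbon bound to an aromatic nitrogen moves this read-out off the limit, and how the four compounds order.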